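Chloro in place of hydrogen: from compound 2 to compound 4

The source may report more compounds than this note shows. Statements on the series, on what has been measured and on what is new or still open speak of the compounds shown alone.

Compound 1 `Nc1sc(-c2cncnc2)cc1C(=O)c1ccccc1`: 2%
Compound 2 `Nc1sc(-c2ccncc2)cc1C(=O)c1ccccc1`: 17%
Compound 3 `CN(C)c1ccc(-c2cc(C(=O)c3ccc(Cl)cc3)c(N)s2)cc1`: 41%

All three were tested in an assay on CHO cells for positive allosteric modulation of adenosine receptor A1 (Homo sapiens), read by ERK phosphorylation, tested at 10 uM; a higher number here means a weaker effect of the compound at the concentration tested, a lower number a stronger effect. Among these numbers compound 2 stands second highest. Its nearest neighbour is compound 1, separated by the step of a number 15 percentage points higher from compound 1 to compound 2 (beyond the scatter), a modest one that is still beyond the scatter. Further away is compound 3, which in this assay gives 41%, a number beyond the scatter above compound 2.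

Compound 4 `Nc1sc(-c2ccncc2)cc1C(=O)c1ccc(Cl)cc1` has not been measured. It differs from compound 2 in one place: chloro in place of hydrogen on an aromatic carbon.

Going by the values given here, no measured step tracks this change on its own. Among the compounds with values here, the only measured step, a number 15 percentage points higher from compound 1 to compound 2 (beyond the scatter), concerns a change on the other ring. Compound 3 carries the same chloro, yet it also carries a different group on the other ring, so its number of 41% cannot be credited to the chloro alone. With the direct evidence missing, no step beyond the scatter is firmly expected for compound 4 in this assay, though a small rise remains possible because compound 3 gives 41%.

Compound 4 is therefore estimated at 22%, within a range from 5% to 45%. The expected step is a number 5 percentage points higher from compound 2 to compound 4 (within the scatter).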

Compound 4, a percentage reported as activity, at one concentration (the size of the read-out at that concentration, not a potency): 17%
Compound 4: middle estimate off by 5 percentage points, on the high side; the measured number falls inside the stated range.
By their numbers in this assay, from the lowest: compound 1; then compounds 2 and 4 (each within the scatter of the next); then compound 3.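

In this assay, going by these compounds alone, there is no change at the digits printed from compound 2 to compound 4 (within the scatter), so turning the phenyl into 4-chlorophenyl leaves the read-out unmoved when the other ring is pyridin-4-yl, the first reading of this change on its own. Compound 3 also carries the 4-chlorophenyl and differs from compound 4 only in the group on the other ring, yet compound 3 gives 41% while compound 4 gives 17%, so the chloro by itself does not bring the higher number seen for compound 3, which goes with that other group. Nothing measured here offers a reason why this position tolerates the chloro without any visible change in the read-out.

The compounds shown leave open whether the chloro would be as silent with the pyrimidin-5-yl of compound 1 on the other ring, where the number is lower to begin with. They also leave open whether this position accepts other groups equally well, such as a methoxy group, an amine or a carboxylic acid, and a reading at a single concentration says nothing about potency.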